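The compounds below may be only part of what the source reports. "The series", "measured", "known", "first", "only" and "open" are said of these compounds alone.

In an ADME assay for permeability, using PAMPA, with a stated time of 30 min, at pH 7.4 (a higher number here means that the compound crosses the layer faster, a lower number that the compound crosses the layer more slowly), the three measured compounds stand as follows:

compound 1, `COc1cccc(CNCCCNc2ccnc3cc(-c4ccc(C(C)(C)C)cc4)ccc23)c1O`, gives 237 10^-6 cm/s
compound 2, `COc1cccc(CNCCCNc2ccnc3cc(CCC(C)C)ccc23)c1O`, gives 23 10^-6 cm/s
compound 3, `COc1ccc(Oc2ccc3c(NCCCNCc4cccc(OC)c4O)ccnc3c2)cc1`, gives 317 10^-6 cm/s

Compound 3 has the highest of the three numbers in this assay. Its nearest neighbour is compound 1, and the step of a 1.3-fold higher number from compound 1 to compound 3 (0.13 log units; within the scatter) lies within the scatter, so these two cannot be ordered. Compound 2 lies furthest away: a 14-fold higher number from compound 2 to compound 3 (1.14 log units; beyond the scatter) is a large step, as is a 10-fold lower number from compound 1 to compound 2 (1.01 log units; beyond the scatter).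

Compound 4, `COc1ccccc1Oc1ccc2c(NCCCNCc3cccc(OC)c3O)ccnc2c1`, is not yet measured. It differs from compound 3 by 2-methoxyphenyl in place of 4-methoxyphenyl on an oxygen on an aromatic ring; the two compounds have the same atoms, joined differently.

Within the data shown here, none of the measured steps compares a 2-methoxyphenoxy group with a 4-methoxyphenoxy group. The steps that come closest exchange the whole group on the shared core: a 1.3-fold higher number from compound 1 to compound 3 (0.13 log units; within the scatter), which stays within the scatter, and a 14-fold higher number from compound 2 to compound 3 (1.14 log units; beyond the scatter), which is large. Among the measured compounds shown here, the change from compound 3 to compound 4 keeps the same group and only rejoins its atoms, and the data hold no step of this kind, so no step beyond the scatter is expected in this assay.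

Compound 4 is therefore expected to give about 300 10^-6 cm/s in this assay, within the range 150 10^-6 cm/s to 600 10^-6 cm/s. The step this estimate means, a 1.1-fold lower number from compound 3 to compound 4 (0.02 log units; within the scatter), is expected to stay within the scatter.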

Compound 4, apparent permeability: 317 10^-6 cm/s
For compound 4 the middle estimate is 1.1-fold (0.02 log units) below the measured one; measured number inside the range.
By their numbers in this assay, from the lowest: compound 2; then compounds 1, 3 and 4 (each within the scatter of the next).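

In this assay, the change from 4-methoxyphenoxy to 2-methoxyphenoxy is the first step shown that rearranges the atoms of one group on an oxygen on an aromatic ring rather than exchanging the group, and it reads as no change at the digits printed from compound 3 to compound 4 (within the scatter), so the two arrangements cannot be told apart at this place. The 2-methoxyphenoxy group also stands where the 4-methoxyphenoxy group stood relative to the other two compounds, with a 14-fold higher number from compound 2 to compound 4 (1.14 log units; beyond the scatter) as a large step away from isopentyl and a 1.3-fold higher number from compound 1 to compound 4 (0.13 log units; within the scatter) leaving it unresolved from 4-(tert-butyl)phenyl. Nothing given here offers an explanation for the match between compound 3 and compound 4.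

The compounds shown vary the methoxy group on this ring only between two arrangements, so it remains open whether a carboxylic acid or an amine in its place would stay with compound 3 and compound 4 or fall towards compound 2. From the compounds shown here alone, it is equally open whether a longer chain in place of isopentyl would stay near compound 2 or move towards the three aryl-bearing compounds.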